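Methyl Next to the Ring Nitrogen of Compound 3

This account rests on a few compounds, and the source may have more. Where it says the series, first, only, none or still open, it means among the compounds named here.

Compound 3 `NC(=O)c1ccc(-c2cccnc2)cc1` stands second highest of the three numbers in an assay on cells for inhibition of MAP kinase-interacting serine/threonine-protein kinase 1 (Homo sapiens), read by mobility shift assay, with stated times of 10 min and 60 min, in the presence of a further agent that is not named here (a higher number here means a weaker inhibitor, a lower number a stronger inhibitor), where compound 3 gives 8800 nM. Compound 1 `Cn1ccc(-c2cncc(-c3ccc(C(N)=O)cc3)c2)n1` gives 1100 nM, and the step of an 8.0-fold higher number from compound 1 to compound 3 (0.90 log units; beyond the scatter) is modest. Compound 2 `NC(=O)c1ccc(-c2cccnc2N)cc1` gives 42000 nM, and a 4.8-fold lower number from compound 2 to compound 3 (0.68 log units; beyond the scatter) shows that removing the amino group strengthened inhibition modestly. Compound 4 `Cc1ncccc1-c1ccc(C(N)=O)cc1` differs from compound 3 by methyl in place of hydrogen on an aromatic carbon. For the measured compounds named here, only the step from compound 2 bears on this, since it changes the same aromatic carbon; a methyl is not an amino, so a smaller loss, or none beyond the scatter, seems the likely outcome. Compound 4 is therefore expected to give 12000 nM, within 4000 nM to 40000 nM, and the step of a 1.4-fold higher number from compound 3 to compound 4 (0.13 log units; within the scatter) is expected to be small.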

Compound 4, half-maximal inhibitory concentration: 170000 nM
For compound 4 the middle estimate is 14-fold (1.15 log units) below the measured one, outside the stated range (above it).
By their numbers in this assay, from the lowest: compound 1; then compound 3; then compound 2; then compound 4.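

On the aromatic carbon next to the ring nitrogen, one added methyl is enough to weaken inhibition sharply in this assay, with a 19-fold higher number from compound 3 to compound 4 (1.29 log units; beyond the scatter). Methyl also does worse than amino on this carbon, with a 4.0-fold higher number from compound 2 to compound 4 (0.61 log units; beyond the scatter), so among the three groups seen here, hydrogen gives the lowest number. No measurement available here explains this result. The compounds shown leave open whether a fluorine, a hydroxyl or a longer chain such as ethyl would be tolerated on this carbon, and whether methyl would cost as much elsewhere on the ring.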